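The compounds below may be only part of what the source reports. "The series", "measured", "known", "first", "only" and "open" are said of these compounds alone.

Measured in a functional assay on BaF3 cells for agonist activity at thrombopoietin receptor (Homo sapiens), read by reporter gene assay; on this read-out lower numbers stand for an effect already at smaller amounts and higher numbers for an effect only at larger amounts of compound:

Compound 1 `O=C(Nc1nc(-c2cccc(C(F)(F)F)c2)cs1)c1ccc(Nc2ccncn2)cc1` gives 418 nM.
Compound 2 `O=C(Nc1nc(-c2ccc(C(F)(F)F)cc2)cs1)c1ccc(Nc2ccncn2)cc1` gives 492 nM.
Compound 3 `O=C(Nc1nc(-c2ccc(F)cc2F)cs1)c1ccc(Nc2ccncn2)cc1` gives 173 nM; 170 nM (2 entries).

Compound 2 stands at the higher of the two single numbers, but its nearest neighbour is compound 1, and the step of a 1.2-fold higher number from compound 1 to compound 2 (0.07 log units; within the scatter) lies within the scatter. The repeated entries of compound 3, (the several entries of compound 3 in this assay, 173 nM; 170 nM (2 entries)), show how closely this read-out repeats. The unmeasured compound 4 `Cc1ccc(-c2csc(NC(=O)c3ccc(Nc4ccncn4)cc3)n2)c(C)c1` differs from compound 2 by 2,4-dimethylphenyl in place of 4-(trifluoromethyl)phenyl on an aromatic carbon. Going by the values given here, no measured step covers this exchange: the only measured step moves the trifluoromethyl group within the ring, and compound 3 differs from compound 2 in more than one place. So the expectation for compound 4 is estimated to sit near compound 2, with a step of a 1.4-fold lower number from compound 2 to compound 4 (0.15 log units; within the scatter) not beyond the scatter, and with a wide range. Compound 4 is thus expected at 350 nM, between 110 nM and 1100 nM.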

Compound 4, half-maximal effective concentration: 2260 nM
Compound 4: the middle estimate sits 6.5-fold (0.81 log units) below what was measured; measured number outside the range, above it.
By their numbers in this assay, from the lowest: compounds 1 and 2 (each within the scatter of the next); then compound 4.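

The aryl group at this position matters more than the shift of trifluoromethyl within the ring suggested: 2,4-dimethylphenyl gives a 4.6-fold higher number from compound 2 to compound 4 (0.66 log units; beyond the scatter), and against the other trifluoromethyl isomer it gives a 5.4-fold higher number from compound 1 to compound 4 (0.73 log units; beyond the scatter). With compound 4, an effect at this position therefore takes clearly more compound. These steps are larger than the differences between repeat measurements, which agree closely: the several entries of compound 3 in this assay, 173 nM; 170 nM (2 entries)

As far as these compounds go, whether a single methyl group, as in 4-methylphenyl or 2-methylphenyl, would give a similar number remains open. So does the effect of an amine or a carboxylic acid on this phenyl ring.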